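The compounds below may be only part of what the source reports. "The series", "measured", "known", "first", "only" and "open" are said of these compounds alone.

Measured in a functional assay on MDA-MB-231 cells (Homo sapiens) for antiproliferative activity, read by sulforhodamine B assay; on this read-out higher numbers stand for weaker inhibition of growth and lower numbers for stronger inhibition of growth:

- Compound 1 `O=C(/C=C/c1ccc(O)cc1)c1c(O)cccc1OCC1CCCC1`: 3410 nM
- Compound 2 `CCCCOc1cccc(O)c1C(=O)/C=C/c1ccc(O)cc1`: > 30000 nM
- Compound 3 `CC(C)COc1cccc(O)c1C(=O)/C=C/c1ccc(O)cc1`: 3520 nM

The entry for compound 2 is a limit of the assay and not a number. That leaves two true numbers, and compound 3 sits level with compound 1 within the scatter.

Compound 4 `O=C(/C=C/c1ccc(O)cc1)c1c(O)cccc1OCc1ccccc1` is still unmeasured. It differs from compound 3 by one change: phenyl in place of isopropyl on a saturated chain carbon bound to an oxygen on an aromatic ring. In short, compound 4 carries phenyl where compound 3 carries isopropyl.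

For the measured compounds named here, three measured steps concern this same place. Isopropyl in place of cyclopentyl gave a 1.0-fold higher number from compound 1 to compound 3 (0.01 log units; within the scatter), so these two groups cannot be told apart here. Propyl in place of cyclopentyl gave an at least 8.7-fold higher number from compound 1 to compound 2 (0.94 log units; beyond the scatter), and isopropyl in place of propyl gave an at least 8.5-fold lower number from compound 2 to compound 3 (0.93 log units; beyond the scatter). The place can therefore matter a great deal, and the propyl compound is the one that breaks from the other two.

Phenyl brings a ring to this carbon, as cyclopentyl does in compound 1 at 3410 nM. No aromatic group has been tested here, so a wide range is sensible, with more room towards weaker inhibition. The expected change is small, within or near the scatter: a 1.1-fold higher number from compound 3 to compound 4 (0.06 log units; within the scatter). For compound 4 the estimated value is 4000 nM, with an expected range from 1500 nM to 15000 nM.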

Compound 4, concentration for 50% growth inhibition: > 30000 nM
Compound 4 ended at the assay's limit; the forecaster's own chance of this, stated with the estimate: 15%; at least 7.5-fold (0.87 log units) between middle value and limit.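

In this assay compound 4 gives > 30000 nM as a limit of the assay and not a number, and it is not alone there: the limit of > 30000 nM in this assay, at which 2 of the 4 values shown sit. Phenyl in place of isopropyl gives an at least 8.5-fold higher number from compound 3 to compound 4 (0.93 log units; beyond the scatter) and phenyl in place of cyclopentyl gives an at least 8.7-fold higher number from compound 1 to compound 4 (0.94 log units; beyond the scatter) and so a ring on this carbon does not by itself keep the growth inhibition seen with cyclopentyl. Compound 1 with its saturated ring stays level with compound 3 and its open branched group, while compound 4 with its aromatic ring shares the limit with the open propyl chain of compound 2, so neither the presence of a ring nor the count of carbons sorts these four compounds, and the step between compound 2 and compound 4 cannot be read.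

Still open, from the compounds shown here alone, is whether a cyclohexyl group here would behave like cyclopentyl, and whether a phenyl ring carrying a fluorine or a methoxy group would return a readable number. Going by these compounds, how far compound 2 and compound 4 lie past the limit also remains unknown.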